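Hydrazone side-chain variation on a shared benzothiazole-free core

This account rests on a few compounds, and the source may have more. Where it says the series, first, only, none or still open, it means among the compounds named here.

Three hydrazones on the same core have been measured in a functional assay on cells (Erythrocyte, Homo sapiens) for inhibition, read by spectrophotometry and hemolysis, with a stated time of 10 min; on this read-out lower numbers stand for stronger inhibition and higher numbers for weaker inhibition. Compound 1 `Cc1cccc2nc(N/N=C\c3ccccc3)sc12` carries a phenyl on the imine carbon and gives 80.1 ug/mL. Compound 2 `Cc1cccc2nc(N/N=C/CC(C)C)sc12`, with a branched saturated chain, gives 90.7 ug/mL. Compound 3 `CC/C=N/Nc1nc2cccc(C)c2s1`, with a short straight chain, gives 78.5 ug/mL. On these numbers compound 3 stands lowest, yet its gap to compound 1 and its gap to compound 2 are both within the scatter, so the three compounds cannot be ordered.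

Compound 4 `CCCCCC/C=N/Nc1nc2cccc(C)c2s1` is the next step. It differs from compound 3 in one place: butyl in place of hydrogen on a saturated chain carbon, two bonds along the chain from a carbon with a double bond to nitrogen. Going by the values given here, the only step that bears on this chain is a 1.2-fold lower number from compound 2 to compound 3 (0.06 log units; within the scatter), which shows that exchanging branched for straight chain left this assay unchanged beyond the scatter. Compound 1 adds that an aromatic substituent in the same position gives a number of the same size. Among the compounds with values here, nothing among the measured steps points to a chain-length effect in either direction.

For compound 4 the expected step is therefore a 1.0-fold lower number from compound 3 to compound 4 (0.02 log units; within the scatter), none beyond the scatter. Compound 4 is estimated at 75 ug/mL, with a range from 40 ug/mL to 150 ug/mL.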

Compound 4, half-maximal inhibitory concentration: 82.2 ug/mL
For compound 4 the middle estimate is 1.1-fold (0.04 log units) below the measured one, and the stated range covers the measured number.
By their numbers in this assay, from the lowest: compounds 3, 1, 4 and 2 (each within the scatter of the next).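

In this assay, going by these compounds alone, the butyl added on a saturated chain carbon, two bonds along the chain from a carbon with a double bond to nitrogen, gives a 1.0-fold higher number from compound 3 to compound 4 (0.02 log units; within the scatter) and so stays within the scatter; this is the first step that changes chain length alone, and the number does not respond to it. The exchange of pentyl for isopropyl on a saturated chain carbon bound to a carbon with a double bond to nitrogen gives a 1.1-fold lower number from compound 2 to compound 4 (0.04 log units; within the scatter) and also stays within the scatter, so the straight hexyl chain and the branched chain of compound 2 cannot be told apart here. No independent data are available to explain this flat response.

Still open, going by these compounds, is whether a chain longer than hexyl, or an amine or a carboxylic acid carried on this chain, would shift the number beyond the scatter. On these data alone, it is also open whether the flat response holds for a hydroxyl or a methoxy group on the phenyl of compound 1, which would test the aromatic side of the series as butyl has tested the saturated side.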